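A few compounds are considered here, and "the series" means these few. Any claim that something is new, unique, unknown or untested is made for them only; others in the source may bear on it.

Three measured members of the series, compound 1 `Cc1ccc(-c2cs/c(=N/NC(=O)CSc3nnnn3-c3ccccc3)n2-c2ccccc2)cc1`, compound 2 `Cn1nnnc1SCC(=O)N/N=c1/scc(-c2ccc(C#N)cc2)n1-c1ccccc1` and compound 3 `O=C(CSc1nnnn1-c1ccccc1)N/N=c1/scc(-c2ccccc2)n1-c1ccccc1`, share one core. In a functional assay on C6 cells (Rattus norvegicus) for cytotoxicity, read by MTT assay, with a stated time of 24 h, tested at 6 ug/mL (on this read-out lower numbers stand for a stronger effect and higher numbers for a weaker effect at the one concentration tested), compound 1 gives 66.8%, compound 2 gives 63.5% and compound 3 gives 52.1%, the lowest of the three, with compound 2 nearest. Within the data shown here, the one single-point step measured so far, a number 14.7 percentage points lower from compound 1 to compound 3 (beyond the scatter), is modest. Compound 4 `N#Cc1ccc(-c2cs/c(=N/NC(=O)CSc3nnnn3-c3ccccc3)n2-c2ccccc2)cc1` differs from compound 3 by cyano in place of hydrogen on an aromatic carbon. Among the measured compounds shown here, no measured step covers this change; compound 2 carries the cyano group too, but differs from compound 3 in a second place, so its value shows only that a cyano-bearing member sits higher than compound 3. Drawing on the substituent step from compound 1 to compound 3, compound 4 is expected to move back up by a number 9.9 percentage points higher from compound 3 to compound 4 (within the scatter), to an estimated 62% in this assay, within 50% to 74%.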

Compound 4, a percentage reported as activity, at one concentration (the size of the read-out at that concentration, not a potency): 78.8%
The estimate for compound 4 lay 16.8 percentage points below the measured number, and the stated range ends below it.
By their numbers in this assay, from the lowest: compound 3; then compounds 2 and 1 (each within the scatter of the next); then compound 4.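

In this assay the change from phenyl to 4-cyanophenyl gives a number 26.7 percentage points higher from compound 3 to compound 4 (beyond the scatter), and cyano in place of methyl on the same aromatic carbon gives a number 12 percentage points higher from compound 1 to compound 4 (beyond the scatter), so hydrogen, methyl and cyano at this carbon read in that rising order. With cyano in place, the group on the aromatic nitrogen also counts: phenyl in place of methyl gives a number 15.3 percentage points higher from compound 2 to compound 4 (beyond the scatter). Nothing available bears on the reason for these steps. Where an amine or a methoxy group on this aromatic carbon would fall remains open. Also open, from the compounds shown here alone, is whether the step from methyl to phenyl on the nitrogen holds with hydrogen on this carbon.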